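The source may hold more compounds than are shown below. What is called first, only, known or untested is meant among the compounds shown, and "the series" means these compounds.

Going by the values given here, in an ADME assay on MT4 cells (Homo sapiens) for cytotoxicity (on this read-out higher numbers stand for lower toxicity in this test and lower numbers for higher toxicity in this test), compound 1 `Cc1cc(C)cc(Cn2c(SCC(=O)Nc3ccccc3[N+](=O)[O-])nc3ccccc32)c1` gives 194000 nM and compound 2 `Cc1cc(C)cc(Cn2c(SCC(=O)Nc3ccccc3[N+](=O)[O-])nc3ccc(Cl)cc32)c1` gives 131000 nM, so compound 1 stands level with the only other number. Compound 3 `Cc1cc(C)cc(S(=O)(=O)n2c(SCC(=O)Nc3ccccc3[N+](=O)[O-])nc3ccccc32)c1` gives only a limit, >= 26000 nM. That limit leaves a step that the limit leaves unreadable from compound 1 to compound 3. Among the compounds with values here, the one readable measurement is a 1.5-fold lower number from compound 1 to compound 2 (0.17 log units; within the scatter).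

Compound 4 `COC(=O)c1ccc(NC(=O)CSc2nc3ccccc3n2Cc2cc(C)cc(C)c2)c(Cl)c1` keeps the core of compound 1 and changes the aryl group on the amide-type nitrogen: 2-chloro-4-(methoxycarbonyl)phenyl in place of 2-nitrophenyl on an amide-type nitrogen. Neither measured step touches that group, so they offer only weak guidance. Within the data shown here, with a 1.5-fold lower number from compound 1 to compound 2 (0.17 log units; within the scatter) as the sole sized step, no shift beyond the scatter is expected in this assay. The expected change is a 1.3-fold lower number from compound 1 to compound 4 (0.11 log units; within the scatter). Compound 4 is estimated at 150000 nM, with an expected range of 50000 nM to 350000 nM.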

Compound 4, half-maximal cytotoxic concentration: 191000 nM
The estimate for compound 4 lay 1.3-fold (0.10 log units) below the measured number, within the range that was stated.
By their numbers in this assay, from the lowest: compounds 2, 4 and 1 (each within the scatter of the next).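

Going by these compounds alone, at the aryl group on the amide-type nitrogen, which no earlier compound varied, 2-chloro-4-(methoxycarbonyl)phenyl in place of 2-nitrophenyl gives in this assay a 1.0-fold lower number from compound 1 to compound 4 (0.01 log units; within the scatter). The two compounds stand level, so on this read-out the 2-nitrophenyl group is not required, at least for this one replacement.

On these data alone, whether a carboxylic acid in place of the methoxycarbonyl, or an amine in place of the chloro, would also stay level remains open. Compound 3 has a limit and not a number, so its step cannot be read: the limit of >= 26000 nM in this assay, at which 1 of the 4 values shown sits.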